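The source may hold more compounds than are shown below. What is called first, only, known or untested is meant among the compounds shown, and "the series" means these compounds.

In a functional assay on DU-145 cells (Homo sapiens) for inhibition, read by trypan blue exclusion, with a stated time of 96 h (a lower number here means a stronger inhibitor of growth, a higher number a weaker inhibitor of growth), compound 3 (`Cc1ccc(S(=O)(=O)/C(=C/c2ccc(C)s2)C(=O)c2ccc(Cl)cc2)cc1`) gives 50000 nM, within the scatter of compound 2 (`COc1ccc(S(=O)(=O)/C(=C/c2ccc(C)s2)C(=O)c2ccc(Cl)cc2)cc1`) at 25000 nM, while compound 1 (`COc1ccccc1/C=C(\C(=O)c1ccc(Cl)cc1)S(=O)(=O)c1ccc(C)cc1`) gives 1000 nM. Compound 4 (`Cc1ccc(/C=C(\C(=O)c2ccc(Cl)cc2)S(=O)(=O)Cc2ccc(F)cc2)s1`) alters the group on the sulfonyl sulfur: 4-fluorobenzyl in place of 4-methylphenyl on a sulfonyl sulfur. Among the measured compounds shown here, the one measured step on that group, a 2.0-fold higher number from compound 2 to compound 3 (0.30 log units; within the scatter), lay within the scatter, but it only placed methyl in place of methoxy on an aromatic carbon. The large 50-fold higher number from compound 1 to compound 3 (1.70 log units; beyond the scatter) concerns a different place and bears only indirectly. For the measured compounds named here, no measured step covers 4-fluorobenzyl, so a modest step toward a lower number in this assay is expected, with wide uncertainty. Compound 4 is estimated at 20000 nM, with an expected range of 3000 nM to 60000 nM. The estimated change is a 2.5-fold lower number from compound 3 to compound 4 (0.40 log units; beyond the scatter).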

Compound 4, concentration for 50% growth inhibition: 50000 nM
The estimate for compound 4 lay 2.5-fold (0.40 log units) below the measured number, and the stated range covers the measured number.
By their numbers in this assay, from the lowest: compound 1; then compounds 2, 3 and 4 (each within the scatter of the next).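

In this assay the group on a sulfonyl sulfur now spans 4-methoxyphenyl, 4-methylphenyl and 4-fluorobenzyl, with the 5-methylthiophen-2-yl group held constant, and the readout stays flat: no change at the digits printed from compound 3 to compound 4 (within the scatter) and a 2.0-fold higher number from compound 2 to compound 4 (0.30 log units; within the scatter) both remain within the scatter. So in this small set, 4-fluorobenzyl separates itself from neither aryl group on that sulfur. No supporting measurement accounts for this flat response. Going by these compounds, it remains open whether the same flatness holds with the 2-methoxyphenyl group of compound 1 in place. On these data alone, the effect of an amine or a carboxylic acid on the group at the sulfonyl sulfur also remains open.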